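Shortening the Amide Substituent in a Mouse Dose Series

The compounds below may be only part of what the source reports. "The series", "measured", "known", "first", "only" and "open" are said of these compounds alone.

Measured so far:
compound 1, `CC(C)NC(=O)/C=C1\CCc2ccc(F)cc21`: 96 mg/kg
compound 2, `NC(=O)/C=C1\CCc2cc(F)cc(F)c21`: 44 mg/kg
compound 3, `Cc1cccc2c1CC/C2=C\C(N)=O`: > 100 mg/kg (a limit, not a number)

These three compounds were tested in a functional assay on the whole organism with Mus musculus as the target; on this read-out higher numbers stand for an effect only at larger amounts of compound and lower numbers for an effect already at smaller amounts. Compound 1 gives 96 mg/kg, the highest of the two numbers reported. Compound 2 gives 44 mg/kg, a lower number, and the gap between the two lies beyond the usual scatter. For compound 3 the assay reports only a limit, and it stands at the limit of > 100 mg/kg in this assay, at which 1 of the 3 values shown sits. No two of these compounds differ in a single place, so no measured step can be read from them.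

Compound 4, `NC(=O)/C=C1\CCc2ccc(F)cc21`, is not yet measured. It differs from compound 1 by hydrogen in place of isopropyl on an amide-type nitrogen, so it keeps the fluorine of compound 1 and carries the same hydrogen on the amide-type nitrogen that compound 2 and compound 3 carry, without being directly comparable to either. The two measured values of compound 1 and compound 2 point toward a lower number when the amide nitrogen carries hydrogen, but compound 3 sits at a limit. The step from compound 1 to compound 4 is expected to be modest and toward a lower number, a 1.6-fold lower number from compound 1 to compound 4 (0.20 log units; within the scatter). Compound 4 is expected to give about 60 mg/kg in this assay, most likely between 25 mg/kg and 130 mg/kg.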

Compound 4, dose for half-maximal effect: 56 mg/kg
Compound 4: the middle estimate sits 1.1-fold (0.03 log units) above what was measured, within the range that was stated.
By their numbers in this assay, from the lowest: compounds 2, 4 and 1 (each within the scatter of the next, the first and the last beyond it). At a limit, above all of these: compound 3.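

For the compounds shown here, compound 4 gives the first comparison in which only one place changes, the group on the amide-type nitrogen, and so the first direct look at that position. In this assay, going from isopropylamino to amino gives a small step (a 1.7-fold lower number from compound 1 to compound 4 (0.23 log units; within the scatter)), which means that removing the isopropyl group and its 3 carbons, with the fluorine and the rest of the shared core unchanged, makes no difference that can be told apart from repeat-measurement scatter. This is new information, as no earlier pair differed in one place only, but nothing shown here offers an explanation for the result.

Going by these compounds alone, no step linking compound 2 or compound 3 to the other compounds can be read, so what the fluorine or methyl groups on the core contribute remains open. Also open, as far as these compounds go, is how this read-out would respond to other groups on the amide-type nitrogen, such as a methyl group, a longer chain like n-butyl, or a chain ending in a carboxylic acid or an amine.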